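The source may hold more compounds than are shown below. What is called first, only, known or untested is meant among the compounds shown, and "the series" means these compounds.

Of the compounds shown here, three sharing one core have been measured in a functional assay on OVCAR-4 cells (Homo sapiens) for inhibition, read by sulforhodamine B assay, with a stated time of 48 h, tested at 10 uM; a higher number here means more inhibition at the concentration tested (going by the name of the read-out), a lower number less inhibition. Compound 1 `Brc1cn2ccnc2c(-c2ccc3ncn(C4CCCCC4)c3c2)n1` gives 9.15%, compound 2 `c1ccc2c(-c3cn4ccnc4c(-c4ccc5ncn(C6CCCCC6)c5c4)n3)cccc2c1` gives 19.7%, and compound 3 `Clc1ccc(-c2cn3ccnc3c(-c3ccc4ncn(C5CCCCC5)c4c3)n2)cc1` gives 4.57%. Compound 3 therefore carries the smallest of the three numbers, though its gap to compound 1 is within the scatter, as the step of a number 4.6 percentage points lower from compound 1 to compound 3 (within the scatter) shows, while the step of a number 15.1 percentage points lower from compound 2 to compound 3 (beyond the scatter) is beyond the scatter.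

Compound 4 `Fc1ccccc1-c1cn2ccnc2c(-c2ccc3ncn(C4CCCCC4)c3c2)n1` has not yet been measured in this assay. It differs from compound 3 by 2-fluorophenyl in place of 4-chlorophenyl on an aromatic carbon. The two steps that touch this aromatic carbon are a number 4.6 percentage points lower from compound 1 to compound 3 (within the scatter) and a number 15.1 percentage points lower from compound 2 to compound 3 (beyond the scatter); both arrive at compound 3, and neither involves a 2-fluorophenyl group, so they bear on this step only indirectly. Exchanging one six-membered carbon ring for another of the same size gave a step within the scatter in one case and a modest one in the other. Compound 4 is therefore expected to sit near compound 3, with a step of a number 3.4 percentage points higher from compound 3 to compound 4 (within the scatter) that does not clearly exceed the scatter, and its estimated inhibition is 8%, within the range -2% to 20%.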

Compound 4, a percentage reported as inhibition, at one concentration (the size of the read-out at that concentration, not a potency): 4.51%
For compound 4 the middle estimate is 3.5 percentage points above the measured one, within the range that was stated.
By their numbers in this assay, from the lowest: compounds 4, 3 and 1 (each within the scatter of the next); then compound 2.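

In this assay, replacing 4-chlorophenyl with 2-fluorophenyl at this position has no readable effect, with a number 0.1 percentage points lower from compound 3 to compound 4 (within the scatter), so these two substituted phenyl groups cannot be told apart here. The bromo group cannot be told apart from 2-fluorophenyl either, with a number 4.6 percentage points lower from compound 1 to compound 4 (within the scatter), whereas a number 15.2 percentage points lower from compound 2 to compound 4 (beyond the scatter) gives a second step beyond the scatter that separates naphthalen-1-yl from a phenyl group, so compound 2 alone stands apart among the four. No measurement is available that would explain these numbers.

The compounds shown leave open how an amine or a carboxylic acid on the phenyl group would read at this position in this assay. They also leave open whether a longer chain in place of the aromatic group would keep the number of compound 2 or fall back towards the others.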